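Methoxy to cyano on the phenyl: an untested swap

A few compounds are considered here, and "the series" means these few. Any claim that something is new, unique, unknown or untested is made for them only; others in the source may bear on it.

compound 1, `COc1ccccc1N1CCN(CCCNc2ncccc2C(=O)NC(C)(C)C)CC1`: 1.26 nM in a functional assay for antagonist activity at Alpha-1A adrenergic receptor (Oryctolagus cuniculus); a higher number here means weaker binding, a lower number tighter binding
compound 2, `COc1ccccc1N1CCN(CCCNc2ncccc2C(=O)N(C)C)CC1`: 1.59 nM in this assay
compound 3, `COc1ccccc1N1CCN(CCCNc2ncc(C#N)cc2C(=O)N(C)C)CC1`: 0.794 nM in this assay

Compound 2 gives the highest of the three numbers in this assay, but only by a small margin: the step of a 1.3-fold higher number from compound 1 to compound 2 (0.10 log units; within the scatter) and the step of a 2.0-fold lower number from compound 2 to compound 3 (0.30 log units; within the scatter) both lie within the scatter, so the three compounds cannot be ranked against one another on these numbers.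

Compound 4, `CN(C)C(=O)c1cccnc1NCCCN1CCN(c2ccccc2C#N)CC1`, is not yet measured. It differs from compound 2 in one place: cyano in place of methoxy on an aromatic carbon. Neither measured step touches this phenyl ring. Going by the values given here, the step from compound 1 to compound 2 alters the amide, and the step from compound 2 to compound 3 adds a cyano group to the other aromatic ring, so no measured step bears directly on the change in compound 4. What the three compounds do show is that every variation tried so far stayed within the scatter. On that basis compound 4 is expected to land near compound 2, with no step beyond the scatter being forecast; the estimate for compound 4 in this assay is 2.5 nM, with a range from 0.8 nM to 8 nM. That estimate corresponds to an expected step of a 1.6-fold higher number from compound 2 to compound 4 (0.20 log units; within the scatter).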

Compound 4, dissociation constant: 2 nM
Estimate against measurement, compound 4: 1.3-fold (0.10 log units) above, and the stated range covers the measured number.
By their numbers in this assay, from the lowest: compounds 3, 1, 2 and 4 (each within the scatter of the next, the first and the last beyond it).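

Going by these compounds alone, compound 4 is the first compound here in which the phenyl ring on the piperazine changes, and in this assay going from 2-methoxyphenyl to 2-cyanophenyl gives a 1.3-fold higher number from compound 2 to compound 4 (0.10 log units; within the scatter) and so leaves the two compounds indistinguishable. Within the data shown here, the earlier compounds varied only the amide and the other aromatic ring, so this pair adds the first reading at this place, ortho to a large group, and shows that the methoxy group can be exchanged for cyano, a group of the same heavy-atom count, without a change that rises above the scatter. Nothing measured here accounts for why the two groups read alike.

On these data alone, it remains open whether a group of a different kind at this place, such as an amine, a carboxylic acid or a longer alkoxy chain, would also stay within the scatter of compound 2. Also open, as far as these compounds go, is whether the 2-cyanophenyl group would read the same when combined with the cyano group of compound 3 or the tert-butyl amide of compound 1.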